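A few compounds are considered here, and "the series" means these few. Any claim that something is new, unique, unknown or untested is made for them only; others in the source may bear on it.

Compound 1 `Oc1cccc(-c2cc(-c3ccccc3)cc(-c3ccsc3)n2)c1`: 75.8%
Compound 2 `Oc1cccc(-c2cc(-c3ccccc3)cc(-c3ccco3)n2)c1`: 10.2%
Compound 3 `Oc1cccc(-c2cc(-c3ccccc3)cc(-c3cccc(O)c3)n2)c1`: 67.2%

In an assay on isolated protein for inhibition of DNA topoisomerase 1 (Homo sapiens), with a stated time of 30 min, tested at 100 uM (on this read-out higher numbers stand for a stronger effect at the one concentration tested and lower numbers for a weaker effect), compound 2 gives 10.2% and stands lowest of the three numbers. Its nearest neighbour is compound 3, and the step of a number 57 percentage points higher from compound 2 to compound 3 (beyond the scatter) is large and lies beyond the scatter. Compound 1 is furthest away, and the step of a number 65.6 percentage points lower from compound 1 to compound 2 (beyond the scatter) is likewise large and beyond the scatter. The step of a number 8.6 percentage points lower from compound 1 to compound 3 (within the scatter) stays within the scatter, so compound 1 and compound 3 cannot be told apart on this read-out.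

Compound 4 `Oc1ccc(-c2cc(-c3ccccc3)cc(-c3ccco3)n2)cc1` has not yet been measured in this assay. It differs from compound 2 in one place: 4-hydroxyphenyl in place of 3-hydroxyphenyl on an aromatic carbon. None of the three measured steps concerns this change; each of them swaps the group that sits meta to the 3-hydroxyphenyl group, while the 3-hydroxyphenyl group itself is unchanged in every measured compound. The measured steps therefore give no direct guide, and compound 4 keeps the furan-2-yl group that is present in compound 2.

Compound 4 is estimated to reach 15%, within a range of 0% to 45%. Among the compounds with values here, this estimate means a step of a number 4.8 percentage points higher from compound 2 to compound 4 (within the scatter), expected to remain within the scatter, because compound 2 gives 10.2% and no measured step speaks for a change at the hydroxyphenyl group.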

Compound 4, a percentage reported as inhibition, at one concentration (the size of the read-out at that concentration, not a potency): 18.6%
Estimate against measurement, compound 4: 3.6 percentage points below, within the range that was stated.
By their numbers in this assay, from the lowest: compounds 2 and 4 (each within the scatter of the next); then compounds 3 and 1 (each within the scatter of the next).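

In this assay, within the data shown here, the step of a number 8.4 percentage points higher from compound 2 to compound 4 (within the scatter) gives the first reading at the position next to the ring nitrogen, since every earlier step changed the group at another place on the core. With the furan-2-yl group retained, 3-hydroxyphenyl and 4-hydroxyphenyl cannot be told apart on this read-out, and compound 4 stays close to compound 2 at the low end of the series, a small change beside the step of a number 57 percentage points higher from compound 2 to compound 3 (beyond the scatter) that lies beyond the scatter. No measured evidence bears on why the two hydroxyphenyl groups read alike here.

The compounds shown leave open whether the two hydroxyphenyl groups would also read alike alongside thiophen-3-yl or 3-hydroxyphenyl, the two partners that gave the higher numbers, since compound 2 and compound 4 both carry furan-2-yl. They also leave open whether a 4-methoxyphenyl group, a 4-aminophenyl group or a phenyl ring bearing a carboxylic acid at this position would move the number, and whether any group here can lift a compound that keeps furan-2-yl out of the low range.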